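This account rests on a few compounds, and the source may have more. Where it says the series, first, only, none or still open, it means among the compounds named here.

Working notes on the dienamide series. In an assay for inhibition of Polyunsaturated fatty acid 5-lipoxygenase (Homo sapiens), read by spectrophotometry, tested at 20 uM (on this read-out higher numbers stand for more inhibition at the one concentration tested (going by the name of the read-out) and lower numbers for less inhibition), compound 1 `CSc1ccc(/C=C/C=C/C(=O)N2CCCCC2)cc1` gives 11.8%. Compound 2 `O=C(/C=C/C=C/c1ccc(Cl)cc1)N1CCCCC1` gives 14.5%. Compound 3 `O=C(/C=C/C=C/c1ccc(O)cc1)N1CCCCC1` gives 44.4%, the highest of the three numbers: a number 29.9 percentage points higher from compound 2 to compound 3 (beyond the scatter), and a number 32.6 percentage points higher from compound 1 to compound 3 (beyond the scatter). Compound 4 `O=C(/C=C/C=C/c1ccccc1)N1CCCCC1` differs from compound 3 by hydrogen in place of hydroxy on an aromatic carbon. For the measured compounds named here, the steps that bear on this are the two in which hydroxy entered, a number 32.6 percentage points higher from compound 1 to compound 3 (beyond the scatter) and a number 29.9 percentage points higher from compound 2 to compound 3 (beyond the scatter), both beyond the scatter, whereas a number 2.7 percentage points higher from compound 1 to compound 2 (within the scatter). Taking the hydroxy away again is therefore expected to fall back toward the level of compound 1 and compound 2, a step estimated as a number 30.4 percentage points lower from compound 3 to compound 4 (beyond the scatter). Compound 4 is accordingly expected to give 14% in this assay, with a range from 4% to 28%.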

Compound 4, a percentage reported as inhibition, at one concentration (the size of the read-out at that concentration, not a potency): 36.3%
Estimate against measurement, compound 4: 22.3 percentage points below, and the stated range ends below it.
By their numbers in this assay, from the lowest: compounds 1 and 2 (each within the scatter of the next); then compounds 4 and 3 (each within the scatter of the next).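

At this position, para to a large group, hydrogen and hydroxy are not told apart in this assay: a number 8.1 percentage points lower from compound 3 to compound 4 (within the scatter). The division among the four compounds lies instead with methylsulfanyl and chloro, with hydrogen in their place giving a number 24.5 percentage points higher from compound 1 to compound 4 (beyond the scatter) and a number 21.8 percentage points higher from compound 2 to compound 4 (beyond the scatter). The earlier hydroxy steps therefore read as a low level with those two groups, not as a gain special to hydroxy. Nothing available accounts for that low level. As far as these compounds go, whether a methoxy, an amine or a carboxylic acid at this position stays with hydrogen and hydroxy or falls with chloro and methylsulfanyl remains open.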